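This account rests on a few compounds, and the source may have more. Where it says the series, first, only, none or still open, it means among the compounds named here.

Compound 1 `O=C(CN(c1nc(Cl)nc2[nH]cnc12)C1CC1)NCC(=O)OCc1ccccc1` — 41.9%
Compound 2 `O=C(O)CNC(=O)CN(c1nc(Cl)nc2[nH]cnc12)C1CC1` — 38.9%

In a functional assay on the whole organism (Tail, strain ICR) with Mus musculus as the target, in the tail flick test, with a stated time of 60 min, at a dose of 25 umol/kg by the oral route (on this read-out lower numbers stand for a weaker effect and higher numbers for a stronger effect at the one dose given), compound 1 gives the higher of the two numbers, though the gap to compound 2, a number 3 percentage points lower from compound 1 to compound 2 (within the scatter), is one the scatter swallows. Compound 3 `CC(C)C[C@H](NC(=O)CN(c1nc(Cl)nc2[nH]cnc12)C1CC1)C(=O)OCc1ccccc1` differs from compound 1 by isobutyl in place of hydrogen on a saturated chain carbon bound to an amide-type nitrogen and a carbonyl carbon. Within the data shown here, no measured step touches that saturated chain carbon; the only known step, at the oxygen next to a carbonyl group, stayed within the scatter and bears only loosely on this change. A step of a number 0.1 percentage points higher from compound 1 to compound 3 (within the scatter) is therefore expected to stay within the scatter. Compound 3 is estimated at 42%, ranging from 25% to 60%.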

Compound 3, a percentage reported as activity, at one dose (the size of the read-out at that dose, not a potency): 27.3%
Estimate against measurement, compound 3: 14.7 percentage points above; the range from low to high includes it.
By their numbers in this assay, from the lowest: compound 3; then compounds 2 and 1 (each within the scatter of the next).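

The saturated chain carbon bound to an amide-type nitrogen and a carbonyl carbon does respond to substitution in this assay: isobutyl in place of hydrogen there brings a number 14.6 percentage points lower from compound 1 to compound 3 (beyond the scatter). Among the compounds shown, this is the first change to move the number beyond the scatter, as the earlier swap of benzyl for hydrogen did not. Nothing measured here says why the number fell.

As far as these compounds go, whether a methyl group, a longer chain or an amine on this carbon would behave like isobutyl stays open. So does whether isobutyl would have a similar effect in compound 2.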